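Removing the methyl group from compound 3

The source may report more compounds than this note shows. Statements on the series, on what has been measured and on what is new or still open speak of the compounds shown alone.

Measured so far in an assay on brain for binding affinity to Adrenergic receptor alpha-1 (Rattus norvegicus), read by radioligand binding; on this read-out higher numbers stand for weaker inhibition and lower numbers for stronger inhibition:
compound 1 `Cc1cc(N2CCc3ccccc3C2)ccn1` gives 5700 nM
compound 2 `Cc1cc(N2CCc3ccccc3C2)cc(NC(=O)CO)n1` gives 20000 nM
compound 3 `Cc1cc(N2CCc3ccccc3C2)cc(N)n1` gives 1500 nM

Compound 3 gives the lowest number of the three. The step of a 3.8-fold lower number from compound 1 to compound 3 (0.58 log units; beyond the scatter) shows what adding the amino group does, and the step of a 13-fold lower number from compound 2 to compound 3 (1.12 log units; beyond the scatter) shows what removing the ((hydroxymethyl)carbonyl) group from that nitrogen does; both run in favour of compound 3, and the step of a 3.5-fold higher number from compound 1 to compound 2 (0.55 log units; beyond the scatter) runs the other way.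

Compound 4 `Nc1cc(N2CCc3ccccc3C2)ccn1` differs from compound 3 in one place: hydrogen in place of methyl on an aromatic carbon. For the measured compounds named here, none of the measured steps touches the methyl group, so no measured step bears directly on this change; all three measured compounds carry it. Going by the values given here, the only guide is that the change is small, one carbon leaving. On that basis compound 4 is expected to show a step of a 1.5-fold higher number from compound 3 to compound 4 (0.17 log units; within the scatter) in this assay, which is within the scatter. Compound 4 is therefore estimated at 2200 nM, with a range from 700 nM to 7000 nM.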

Compound 4, inhibition constant: 2100 nM
Compound 4: middle estimate off by 1.0-fold (0.02 log units), on the high side, within the range that was stated.
By their numbers in this assay, from the lowest: compounds 3 and 4 (each within the scatter of the next); then compound 1; then compound 2.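

In this assay, the step of a 1.4-fold higher number from compound 3 to compound 4 (0.15 log units; within the scatter) shows that, with the amino group in place, the methyl on the aromatic carbon next to the ring nitrogen can be exchanged for hydrogen without a change that can be read beyond the scatter. The step of a 2.7-fold lower number from compound 1 to compound 4 (0.43 log units; beyond the scatter), with amino in place of methyl, shows that the lower number seen with the amino group does not depend on the methyl group staying on the ring. Nothing given here accounts for either result.

Going by these compounds, whether an ethyl group, a chlorine or a methoxy group in place of that methyl would shift the number remains open. So does the value of the core with hydrogen in place of both the methyl and the amino group.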